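Adding a methyl to the hydroxy group of compound 1

The source may report more compounds than this note shows. Statements on the series, on what has been measured and on what is new or still open speak of the compounds shown alone.

For the measured compounds named here, in a functional assay on A549 cells (Homo sapiens) for cytotoxicity, read by sulforhodamine B assay, with a stated time of 48 h (on this read-out lower numbers stand for stronger inhibition and higher numbers for weaker inhibition), compound 1 (`COc1ccc(/C=C/C(=O)c2ccc(N)c(-c3ccc(F)cc3)c2)cc1O`) gives 940 nM, the lowest of the three numbers measured so far. Compound 2 (`COc1ccc(/C=C/C(=O)c2cccc(-c3ccc(F)cc3)c2)cc1`) gives 11200 nM and compound 3 (`COc1ccccc1/C=C/C(=O)c1cccc(-c2cccc(F)c2)c1`) gives 15500 nM, both well beyond the usual scatter from compound 1. Neither carries the hydroxy group, but each also differs from compound 1 in other places, so their numbers cannot show what the hydroxy group alone contributes.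

Compound 4 (`COc1ccc(/C=C/C(=O)c2ccc(N)c(-c3ccc(F)cc3)c2)cc1OC`) alters compound 1 in one place only: methyl in place of hydrogen on an oxygen on an aromatic ring, which turns hydroxy to methoxy. Going by the values given here, no measured pair tests this single change. The value of compound 2, 11200 nM, gives only a weak hint that losing the hydroxy group may cost some inhibition.

A small move towards a higher number is therefore expected, probably not beyond the scatter. The estimated change is a 1.7-fold higher number from compound 1 to compound 4 (0.23 log units; within the scatter). For compound 4, the expected value is 1600 nM, within an estimated range of 500 nM to 5000 nM.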

Compound 4, half-maximal inhibitory concentration: 8630 nM
Compound 4: the middle estimate sits 5.4-fold (0.73 log units) below what was measured; measured number outside the range, above it.
By their numbers in this assay, from the lowest: compound 1; then compounds 4, 2 and 3 (each within the scatter of the next).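

For the compounds shown here, this is the first step that isolates one change. In this assay, hydroxy to methoxy, with the rest of the molecule unchanged, gives a 9.2-fold higher number from compound 1 to compound 4 (0.96 log units; beyond the scatter). A single added carbon on this oxygen is therefore enough to weaken inhibition clearly in this setting, something the earlier compounds could only hint at, since they differ from compound 1 in other places too; no measurement shown here gives a reason for this loss.

From the compounds shown here alone, what stays open is whether the loss comes from removing the hydrogen on the oxygen or from adding the methyl. An ethyl on the same oxygen, or a fluorine or an amine in place of the hydroxy group, would help separate these two readings.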